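Sulfanyl in place of chloro on the core of compound 1

This account rests on a few compounds, and the source may have more. Where it says the series, first, only, none or still open, it means among the compounds named here.

In an ADME assay on KB cells (Homo sapiens) for cytotoxicity (a higher number here means that more compound is needed for the effect, a lower number that less compound is needed), compound 1 (`Nc1nc(Cl)c2ncn(C3CC(O)C(CO)C3)c2n1`) gives 62 ug/mL as its half-maximal concentration, and compound 2 (`Nc1nc(O)c2ncn([C@@H]3C[C@H](CO)[C@@H](O)C3)c2n1`) gives 95 ug/mL on the same read-out. Within the data shown here, these two numbers lie within the scatter of each other, so compound 1 stands level with the only other measured member of the series.

Compound 3 (`Nc1nc(S)c2ncn(C3CC(O)C(CO)C3)c2n1`) carries sulfanyl in place of chloro on an aromatic carbon, next to the ring nitrogen (sulfanyl in place of chloro on an aromatic carbon) with the rest of compound 1 unchanged. Among the measured compounds shown here, no measured pair differs in one place only, so the data give no step size to lean on. From the structural change alone, a move to a lower number in this assay is expected, beyond the scatter. The estimated change is a 10-fold lower number from compound 1 to compound 3 (1.01 log units; beyond the scatter) and remains uncertain. For compound 3 the expected value is 6 ug/mL with an estimated range of 1 ug/mL to 35 ug/mL on repeated measurement.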

Compound 3, concentration for half-maximal effect: > 100 ug/mL
Compound 3 gave a limit, no number; the forecaster's own chance of this, stated with the estimate: 5%; at least 16-fold (1.22 log units) between middle value and limit.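

Compound 3 gives only a limit of the assay in this assay, not a number: the limit of > 100 ug/mL in this assay, at which 1 of the 3 values shown sits.

Sulfanyl in place of chloro on an aromatic carbon, next to the ring nitrogen, supplies the first one-place step in the series, read as an at least 1.6-fold higher number from compound 1 to compound 3 (0.20 log units; that floor lies within the scatter). The step runs towards a higher number, so this change gives no sign of a lower number at this position. Its floor alone does not separate the two compounds, and the full size of the step cannot be read.

On these data alone, how far the true value of compound 3 lies past the limit remains open. Also open, as far as these compounds go, is how this position responds to other groups, such as a methylamino or methoxy group in place of chloro on the same aromatic carbon.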